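The source may report more compounds than this note shows. Statements on the series, on what has been measured and on what is new or still open speak of the compounds shown alone.

Going by the values given here, compound 1 `COc1cc(-c2nnc3n2NC(c2ccco2)C(C(=O)c2ccc(Cl)cc2)S3)cc(OC)c1OC` is one of three compounds measured in a functional assay on HepG2 cells (Homo sapiens) for cytotoxicity, read by MTT assay, with a stated time of 48 h (on this read-out lower numbers stand for stronger inhibition and higher numbers for weaker inhibition), where compound 1 gives 78600 nM. Compound 2 `COc1cc(-c2nnc3n2NC(c2cccs2)C(C(=O)c2ccccc2)S3)cc(OC)c1OC` reaches only a limit of this assay, > 100000 nM. Compound 3 `COc1cc(C(=O)C2Sc3nnc(-c4cc(OC)c(OC)c(OC)c4)n3NC2c2cccs2)cc(OC)c1OC` likewise reaches only a limit, > 100000 nM. Among the compounds with values here, the single step between measured compounds that differ in one place, a step that the two limits leave unreadable from compound 2 to compound 3, puts a 3,4,5-trimethoxyphenyl in place of a phenyl on the carbonyl carbon, and its size cannot be read. Within the data shown here, compound 1 therefore stands as the only real number in this assay; the other two values sit at the limit of > 100000 nM in this assay, at which 2 of the 3 values shown sit.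

Compound 4 `COc1cc(-c2nnc3n2NC(c2ccco2)C(C(=O)c2ccc(O)cc2)S3)cc(OC)c1OC` differs from compound 1 by hydroxy in place of chloro on an aromatic carbon, that is, a 4-chlorophenyl carbonyl becomes a 4-hydroxyphenyl carbonyl. Among the measured compounds shown here, none of the measured steps touches this position or this kind of exchange, so no measured step bears on it, and the expectation for compound 4 rests only on where compound 1 sits, close to the limit. The step of a 1.3-fold higher number from compound 1 to compound 4 (0.10 log units; within the scatter) is expected to stay within the usual scatter, with a real chance that only a limit is reported. On that basis compound 4 is estimated at 100000 nM, with a range from 40000 nM to 250000 nM.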

Compound 4, half-maximal inhibitory concentration: > 100000 nM
Compound 4 was reported as a limit; the forecaster's own chance of this, stated with the estimate: 50%; the middle value sits exactly at the limit.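

Going by these compounds alone, the exchange of chloro for hydroxy on the aromatic ring of the carbonyl group is the first measured change at this position, and in this assay it reads as an at least 1.2-fold higher number from compound 1 to compound 4 (0.10 log units; that floor lies within the scatter). This figure is only a floor, so the data cannot show whether the change truly weakens the effect on the cells, but they do show that the 4-hydroxyphenyl carbonyl gives no measurable number in this assay, unlike the 4-chlorophenyl carbonyl of compound 1. Compound 1 therefore remains the only compound here with a real number, and any comparison with it is restricted by the ceiling that most of the series has reached: the limit of > 100000 nM in this assay, at which 3 of the 4 values shown sit.

The true distance between compound 4 and compound 1 remains unknown, and so does the question of whether chloro itself matters, as no compound shown pairs the furan-bearing core with a plain phenyl carbonyl. Also open, on these data alone, is whether an amine or a carboxylic acid in place of chloro on this aromatic carbon would give a lower number than compound 1 or would likewise end at the limit.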